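Expected clearance when a benzothiophene replaces a methylthiophene

The source may report more compounds than this note shows. Statements on the series, on what has been measured and on what is new or still open speak of the compounds shown alone.

Of the compounds shown here, three built on one shared core have been tested in an ADME assay (liver) for metabolic stability, with Liver microsome (Rattus norvegicus) as the target, using microsomes and NADPH, with a stated time of 30 min, tested at 1 uM; on this read-out lower numbers stand for slow clearance and higher numbers for fast clearance. Compound 1 `CCn1cc(-c2cc(C(O)(C(F)(F)F)C(F)(F)F)cnc2N2CCN(S(=O)(=O)c3ccc(N)nc3)CC2)cn1` gives 194 mL.min-1.g-1. Compound 2 `Cc1csc(-c2cc(C(O)(C(F)(F)F)C(F)(F)F)cnc2N2CCN(S(=O)(=O)c3ccc(N)nc3)CC2)c1` gives 399 mL.min-1.g-1. Compound 3 `Nc1ccc(S(=O)(=O)N2CCN(c3ncc(C(O)(C(F)(F)F)C(F)(F)F)cc3-c3cc4ccccc4[nH]3)CC2)cn1` gives 146 mL.min-1.g-1. Among these three, compound 2 stands highest: the step of a 2.1-fold higher number from compound 1 to compound 2 (0.31 log units; beyond the scatter) and the step of a 2.7-fold lower number from compound 2 to compound 3 (0.44 log units; beyond the scatter) both lie beyond the scatter, whereas the step of a 1.3-fold lower number from compound 1 to compound 3 (0.12 log units; within the scatter) does not, so compounds 1 and 3 cannot be ordered against each other.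

Compound 4 `Nc1ccc(S(=O)(=O)N2CCN(c3ncc(C(O)(C(F)(F)F)C(F)(F)F)cc3-c3cc4ccccc4s3)CC2)cn1` has not yet been measured in this assay. It differs from compound 2 in a single place: 1-benzothiophen-2-yl in place of 4-methylthiophen-2-yl on an aromatic carbon

The nearest guide is the step from compound 2 to compound 3, in which the 1H-indol-2-yl group replaced the 4-methylthiophen-2-yl group and the number fell by a 2.7-fold lower number from compound 2 to compound 3 (0.44 log units; beyond the scatter). For the measured compounds named here, the 1-benzothiophen-2-yl group keeps the sulfur of the leaving group, and no measured pair shows this exact exchange, so the direction is uncertain. The expected step of a 1.3-fold lower number from compound 2 to compound 4 (0.12 log units; within the scatter) is a modest move downward from compound 2, with wide uncertainty. Compound 4 is therefore estimated at 300 mL.min-1.g-1, within a range from 130 mL.min-1.g-1 to 700 mL.min-1.g-1.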

Compound 4, intrinsic clearance in microsomes: 315 mL.min-1.g-1
The estimate for compound 4 lay 1.1-fold (0.02 log units) below the measured number, and the stated range covers the measured number.
By their numbers in this assay, from the lowest: compounds 3, 1, 4 and 2 (each within the scatter of the next, the first and the last beyond it).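

The new compound separates two groups that the earlier set could not: with two fused aromatic rings at this position, the step of a 2.2-fold higher number from compound 3 to compound 4 (0.33 log units; beyond the scatter) lies beyond the scatter, so 1-benzothiophen-2-yl and 1H-indol-2-yl are not interchangeable here, and carrying a second ring does not by itself fix the clearance number. The extra six-membered aromatic ring of carbon only, which also comes with the loss of the methyl group, gives no readable difference in the step of a 1.3-fold lower number from compound 2 to compound 4 (0.10 log units; within the scatter), which stays within the scatter; compound 2 and compound 4, the two sulfur-containing members, therefore cannot be ordered against each other, although compound 1 complicates any simple grouping by sulfur, since the step of a 1.6-fold higher number from compound 1 to compound 4 (0.21 log units; within the scatter) also stays within the scatter even though compound 1 and compound 2 lie beyond it. Nothing shown here explains why these groups behave as they do.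

The compounds leave open whether a thiophen-2-yl group without the methyl would read like compound 2, and whether 1-benzofuran-2-yl, with oxygen in the ring in place of sulfur, would fall nearer compound 3 or compound 4. Going by these compounds, how a non-aromatic group at this position, such as an amine like morpholine, would read also remains open.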